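The compounds below may be only part of what the source reports. "The series", "measured", "known", "first", "only" and "open" are said of these compounds alone.

Of the compounds shown here, three have so far been measured in an assay on 3T3-L1 cells for inhibition of diacylglycerol O-acyltransferase 1 (Mus musculus); a higher number here means a weaker inhibitor, a lower number a stronger inhibitor. Compound 1 `Cn1c(OCC(C)(C)C(=O)Nc2ccccc2)nnc1-c1ccc(NC(=O)c2ccc3ccccc3c2)cc1` gives 220 nM in this assay. Compound 2 `CN(C)C(=O)C(C)(C)COc1nnc(-c2ccc(NC(=O)c3ccc4ccccc4c3)cc2)n1C` gives 440 nM, and compound 3 `CC(C)(COc1ccc(-c2ccc(NC(=O)c3ccc4ccccc4c3)cc2)cn1)C(=O)O`, which has a different core and a carboxylic acid where the other two carry an amide, gives 37 nM. Compound 2 therefore stands highest of the three numbers. Its nearest neighbour is compound 1, and that step, a 2.0-fold higher number from compound 1 to compound 2 (0.30 log units; within the scatter), lies within the scatter; compound 3 stands furthest from it, with a number beyond the scatter below.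

Compound 4 `Cn1c(OCC(C)(C)C(N)=O)nnc1-c1ccc(NC(=O)c2ccc3ccccc3c2)cc1` differs from compound 2 in one place: amino in place of dimethylamino on a carbonyl carbon. For the measured compounds named here, the only measured step that bears on this position is a 2.0-fold higher number from compound 1 to compound 2 (0.30 log units; within the scatter), in which one amide substituent replaced another and the number moved within the scatter. Nothing measured here speaks to a primary amide at this position, so the expectation rests on that single step alone, and it points to no change beyond the scatter in this assay. The expected step is a 1.3-fold lower number from compound 2 to compound 4 (0.10 log units; within the scatter). For compound 4 the estimate is 350 nM, with a range from 120 nM to 1000 nM.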

Compound 4, half-maximal inhibitory concentration: 6100 nM
Compound 4: the middle estimate sits 17-fold (1.24 log units) below what was measured; the measured number lies above the stated range.
By their numbers in this assay, from the lowest: compound 3; then compounds 1 and 2 (each within the scatter of the next); then compound 4.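

Replacing dimethylamino with amino on the carbonyl carbon gives a 14-fold higher number from compound 2 to compound 4 (1.14 log units; beyond the scatter) in this assay, and hydrogen in place of phenyl on the amide-type nitrogen gives a 28-fold higher number from compound 1 to compound 4 (1.44 log units; beyond the scatter), so this position is not indifferent to every change of amide substituent. The earlier step, a 2.0-fold higher number from compound 1 to compound 2 (0.30 log units; within the scatter), had shown only that anilino and dimethylamino could not be told apart here; the new result shows that this does not extend to the unsubstituted carbamoyl group, the only one of the three amides with no carbon group on its nitrogen, while compound 1 also keeps an amide hydrogen, so that hydrogen alone does not go with the higher number. No available evidence bears on why the number rises with this change.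

The compounds shown leave open whether a single small carbon group on the nitrogen, as in methylamino or ethylamino, would bring the number back to the level of the substituted amides. They also leave open how a carboxylic acid in place of the amide would behave on the shared core of compound 1, since the acid shown sits on a different core.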